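Trifluoromethoxy for fluoro on the aryl amide of compound 1

The source may hold more compounds than are shown below. What is called first, only, known or untested is meant among the compounds shown, and "the series" means these compounds.

Measured so far:
compound 1 `CC(C)N(C(=O)CN1C=CN(c2ccccc2)C(=O)C(Cc2n[nH]c3ccccc23)C1=O)c1ccc(F)cc1`: 50.1 nM
compound 2 `CC(C)N(C(=O)CN1C=CN(c2ccccc2)C(=O)C(Cc2n[nH]c3ccccc23)C1=O)c1ccc(O)cc1`: 550 nM; 158 nM; 52.5 nM (3 entries)
compound 3 `COC1(Cc2n[nH]c3ccccc23)C(=O)N(CC(=O)N(c2ccc(F)cc2)C(C)C)C=CN(c2ccccc2)C1=O`: 2950 nM

All were read in a functional assay on CHO cells for agonist activity at Melanocyte-stimulating hormone receptor (Homo sapiens), read by a luciferase reporter, with a stated time of 4 h; on this read-out higher numbers stand for an effect only at larger amounts of compound and lower numbers for an effect already at smaller amounts. Among the compounds with values here, compound 1 holds the lowest of the two single numbers; the one recorded step, a 59-fold higher number from compound 1 to compound 3 (1.77 log units; beyond the scatter), came from methoxy in place of hydrogen on a saturated ring carbon. Compound 2 has three entries, (the several entries of compound 2 in this assay, 550 nM; 158 nM; 52.5 nM (3 entries)), spread beyond the scatter, so where it stands against compound 1 is unsettled.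

Compound 4 `CC(C)N(C(=O)CN1C=CN(c2ccccc2)C(=O)C(Cc2n[nH]c3ccccc23)C1=O)c1ccc(OC(F)(F)F)cc1` differs from compound 1 by trifluoromethoxy in place of fluoro on an aromatic carbon. Within the data shown here, no recorded step touches this aromatic ring; the entries of compound 2 show only that a change at this aromatic carbon can read anywhere from near compound 1 to well above it. A modest step, direction open, is therefore expected, a 2.0-fold higher number from compound 1 to compound 4 (0.30 log units; within the scatter). Compound 4 is estimated at 100 nM, between 25 nM and 400 nM.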

Compound 4, half-maximal effective concentration: 22.4 nM
Beside the measured number, compound 4's estimate is 4.5-fold (0.65 log units) above it, and the stated range ends above it.
By their numbers in this assay, from the lowest: compound 4; then compound 1; then compound 3.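

This aromatic carbon accepts trifluoromethoxy with no rise in the number: in this assay, the change gives a 2.2-fold lower number from compound 1 to compound 4 (0.35 log units; beyond the scatter). Within the data shown here, it is the first recorded step on this ring and a modest one, much smaller than the step at the saturated ring carbon, a 59-fold higher number from compound 1 to compound 3 (1.77 log units; beyond the scatter). Compound 2, with hydroxy at this carbon, stays unplaced against compound 4, its entries spreading widely: the several entries of compound 2 in this assay, 550 nM; 158 nM; 52.5 nM (3 entries)

Open, as far as these compounds go, is how an amine, a carboxylic acid or a longer alkoxy chain would read at this carbon. Also open, from the compounds shown here alone, is whether trifluoromethoxy gives the same step alongside the methoxy of compound 3.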